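A few compounds are considered here, and "the series" means these few. Any claim that something is new, unique, unknown or untested is made for them only; others in the source may bear on it.

Three compounds share one core and differ only in the ring attached to the carbonyl carbon. Compound 1 `O=C(/C=C/c1ccc2c(c1)B(O)OC2)c1ccco1` carries a furan-2-yl there, and in a functional assay on SK-OV-3 cells (Homo sapiens) for cytotoxicity, read by MTT assay, with a stated time of 48 h (a higher number here means a weaker inhibitor, a lower number a stronger inhibitor), compound 1 gives 20700 nM. Compound 2 `O=C(/C=C/c1ccc2c(c1)B(O)OC2)c1cccnc1` carries a pyridin-3-yl instead, and compound 2 gives 18500 nM, so that a 1.1-fold lower number from compound 1 to compound 2 (0.05 log units; within the scatter). Compound 3 `O=C(/C=C/c1ccc2c(c1)B(O)OC2)c1ccc(Cl)cc1` carries a 4-chlorophenyl, and compound 3 gives 3700 nM; here a 5.6-fold lower number from compound 1 to compound 3 (0.75 log units; beyond the scatter) and a 5.0-fold lower number from compound 2 to compound 3 (0.70 log units; beyond the scatter). Compound 3 thus stands lowest of the three numbers, with both other compounds separated from it by more than the scatter.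

Compound 4 `Cc1ccc(C(=O)/C=C/c2ccc3c(c2)B(O)OC3)cc1` keeps that same ring but has methyl in place of chloro on an aromatic carbon, on an aromatic carbon of a six-membered aromatic ring of carbon only, para to a large group. For the measured compounds named here, none of the measured steps swaps one substituent for another on this ring; they only compare whole rings, so they give no direct guide to the size or direction of this change. The expectation is therefore a small step, a 1.4-fold higher number from compound 3 to compound 4 (0.13 log units; within the scatter), within the scatter. Compound 4 is expected to give about 5000 nM in this assay, with a likely range from 2000 nM to 15000 nM.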

Compound 4, half-maximal inhibitory concentration: 3700 nM
Compound 4: the middle estimate sits 1.4-fold (0.13 log units) above what was measured, within the range that was stated.
By their numbers in this assay, from the lowest: compounds 3 and 4 (each within the scatter of the next); then compounds 2 and 1 (each within the scatter of the next).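

For the compounds shown here, replacing chloro with methyl on an aromatic carbon, para to a large group, gives no change at the digits printed from compound 3 to compound 4 (within the scatter) in this assay, the first direct comparison of two substituents on this ring. The 4-methylphenyl compound also stands apart from the other two rings, with a 5.0-fold lower number from compound 2 to compound 4 (0.70 log units; beyond the scatter) and a 5.6-fold lower number from compound 1 to compound 4 (0.75 log units; beyond the scatter), so at this position the assay does not tell these two groups apart. No measurement is available that would explain this result.

As far as these compounds go, it remains open whether an amine, a methoxy group or a carboxylic acid in the same place would give a similar number, and how a plain phenyl ring with no substituent would compare. From the compounds shown here alone, with only chloro and methyl at this position, the contribution of the substituent itself to the difference from the furan-2-yl and pyridin-3-yl compounds also remains unknown.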